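Exchanging One Aromatic Ring on Compound 3

The source may hold more compounds than are shown below. What is called first, only, known or untested is meant among the compounds shown, and "the series" means these compounds.

In an in vitro ADME assay on microsomes from liver (Homo sapiens) for pharmacokinetics (on this read-out higher numbers stand for fast clearance and lower numbers for slow clearance), compound 1 (`CC(=O)N[C@@H](CCN1C[C@@H]2CN(C(=O)c3ccccc3)C[C@@H]2C1)c1ccccc1`) gives 70 mL.min-1.g-1 and compound 2 (`CC(=O)N[C@@H](CCN1C[C@@H]2CN(C(=O)c3cccc(F)c3)C[C@@H]2C1)c1cccc(F)c1`) gives 213 mL.min-1.g-1. Compound 3 (`O=C(N[C@@H](CCN1C[C@@H]2CN(C(=O)c3cccc(F)c3)C[C@@H]2C1)c1cccc(F)c1)C1CCOC1`) gives 331 mL.min-1.g-1, the highest of the three numbers. It is clearly above compound 1, but not clearly apart from compound 2: a 1.6-fold higher number from compound 2 to compound 3 (0.19 log units; within the scatter) is a step within the scatter, with oxolan-3-yl in place of methyl on a carbonyl carbon.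

Compound 4 (`O=C(N[C@@H](CCN1C[C@@H]2CN(C(=O)c3ccccn3)C[C@@H]2C1)c1cccc(F)c1)C1CCOC1`) differs from compound 3 by one exchange: pyridin-2-yl in place of 3-fluorophenyl on a carbonyl carbon. Here pyridin-2-yl stands in place of 3-fluorophenyl on a carbonyl carbon whose other neighbour is an amide-type nitrogen in a ring. The step measured so far lies at a different place, so it says little about this exchange. Going by the values given here, the only hint comes from compound 1, which lacks 3-fluorophenyl on that carbonyl and shows 70 mL.min-1.g-1, against 213 mL.min-1.g-1 for compound 2. That pair also differs elsewhere, so the hint is weak. A modest move to a lower number is therefore expected, with wide uncertainty. The expected change is a 2.2-fold lower number from compound 3 to compound 4 (0.34 log units; beyond the scatter). For compound 4 the estimated value is 150 mL.min-1.g-1, with an expected range of 65 mL.min-1.g-1 to 340 mL.min-1.g-1.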

Compound 4, intrinsic clearance in microsomes: 55 mL.min-1.g-1
Estimate against measurement, compound 4: 2.7-fold (0.44 log units) above; the measured number lies below the stated range.
By their numbers in this assay, from the lowest: compounds 4 and 1 (each within the scatter of the next); then compounds 2 and 3 (each within the scatter of the next).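

In this assay, the carbonyl carbon whose other neighbour is an amide-type nitrogen in a ring proves to be a sensitive place: pyridin-2-yl in place of 3-fluorophenyl gives a 6.0-fold lower number from compound 3 to compound 4 (0.78 log units; beyond the scatter), a clear shift towards slow clearance. Going by these compounds alone, the only other single exchange measured in this set, oxolan-3-yl in place of methyl at a different carbonyl, stayed within the scatter, so this is the first one-place change here that moves the number beyond it. The exchange removes a fluorine and a carbon-only ring and brings in a ring with one nitrogen and one hydrogen-bond acceptor, but no measurement at hand links the lower clearance number to any one of these differences.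

The compounds shown leave open whether the lower number belongs to the ring nitrogen or to the loss of fluorine, and whether the same exchange would have a similar effect with methyl in place of oxolan-3-yl. Also open, from the compounds shown here alone, is whether the place of the nitrogen in the ring counts, which pyridin-3-yl or pyrimidin-2-yl on the same carbonyl carbon could show.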